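Nitrile Substitution Carried From One Core to Another

This account rests on a few compounds, and the source may have more. Where it says the series, first, only, none or still open, it means among the compounds named here.

Compound 1 `O=C(NCc1ccc(OCc2ccccc2)cc1)n1cccn1` and compound 2 `N#Cc1cnn(C(=O)NCc2ccc(OCc3ccccc3)cc2)c1` share one core; compound 2 differs from compound 1 by cyano in place of hydrogen on an aromatic carbon. In an assay on membranes from brain for binding affinity to Fatty-acid amide hydrolase 1 (Mus musculus), read by fluorescence, with stated times of 1 h and 30 min (on this read-out lower numbers stand for stronger inhibition and higher numbers for weaker inhibition), compound 1 gives 800 nM, while compound 2 gives 60 nM, so that a 13-fold lower number from compound 1 to compound 2 (1.12 log units; beyond the scatter). Compound 3 `O=C(N1CCN(C(c2ccc3ccccc3c2)c2ccc3ccccc3c2)CC1)n1cccn1` carries the same five-membered aromatic ring with 2 nitrogen on a different core; the difference between the two cores is not broken down here. In this assay compound 3 reaches only a limit, > 100000 nM, recorded as the limit of > 100000 nM in this assay, at which 1 of the 3 values shown sits. Compound 4 `N#Cc1cnn(C(=O)N2CCN(C(c3ccc4ccccc4c3)c3ccc4ccccc4c3)CC2)c1` is compound 3 with cyano in place of hydrogen on an aromatic carbon, the same change as between compound 1 and compound 2. For the measured compounds named here, because compound 3 stands at the limit of > 100000 nM in this assay, at which 1 of the 3 values shown sits, no numeric step can be drawn from it. By analogy with a 13-fold lower number from compound 1 to compound 2 (1.12 log units; beyond the scatter) the change is expected to give an at least 3.3-fold lower number from compound 3 to compound 4 (0.52 log units; beyond the scatter). Compound 4 is estimated at 30000 nM, between 5000 nM and 100000 nM, and may itself remain a limit.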

Compound 4, half-maximal inhibitory concentration: > 100000 nM
Compound 4 ended at the assay's limit; the forecaster's own chance of this, stated with the estimate: 50%; middle value at least 3.3-fold (0.52 log units) away from the limit.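

Compound 3 and compound 4 both stand at a limit and not at a number, so no step can be read between them: the limit of > 100000 nM in this assay, at which 2 of the 4 values shown sit.

As far as these compounds go, whether cyano in place of hydrogen changes anything on the core of compound 3, as it does on the core of compound 1, stays open.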